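Cyclic sulfone with hydroxyl at the ether-linked position

The source may hold more compounds than are shown below. What is called first, only, known or untested is meant among the compounds shown, and "the series" means these compounds.

Measured compounds:
Compound 1 `Cc1nc(C)c(COc2cc(C)c(-c3cccc(COc4ccc5c(c4)OC[C@H]5CC(=O)O)c3)c(C)c2)s1` — 18 nM
Compound 2 `CCS(=O)(=O)CCOc1cc(C)c(-c2cccc(COc3ccc4c(c3)OC[C@H]4CC(=O)O)c2)c(C)c1` — 14 nM

In a functional assay on CHO cells for agonist activity at Free fatty acid receptor 1 (Homo sapiens), read by FLIPR and calcium flux, with a stated time of 90 s, in the presence of a further agent that is not named here (on this read-out higher numbers stand for an effect only at larger amounts of compound and lower numbers for an effect already at smaller amounts), compound 1 gives 18 nM, and in this assay compound 2 gives 14 nM. For the measured compounds named here, compound 2 is thus one of only two compounds measured, and the step of a 1.3-fold lower number from compound 1 to compound 2 (0.11 log units; within the scatter) places it within the usual scatter of compound 1 rather than apart from it.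

Compound 3 `Cc1cc(OCC2(O)CCS(=O)(=O)CC2)cc(C)c1-c1cccc(COc2ccc3c(c2)OC[C@H]3CC(=O)O)c1` has not yet been measured. It differs from compound 2 by 4-hydroxy-1,1-dioxothian-4-yl in place of (ethylsulfonyl)methyl on a saturated chain carbon bound to an oxygen on an aromatic ring. Going by the values given here, the one measured step at this position, a 1.3-fold lower number from compound 1 to compound 2 (0.11 log units; within the scatter), was small, which gives no ground to expect a change beyond the scatter from a further exchange of the group at the same place. Compound 3 is therefore expected to stay close to compound 2, with an expected step of a 1.1-fold higher number from compound 2 to compound 3 (0.06 log units; within the scatter). The estimate for compound 3 in this assay is 16 nM, with a range from 5 nM to 50 nM.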

Compound 3, half-maximal effective concentration in the Free fatty acid receptor 1 assay: 13 nM
Beside the measured number, compound 3's estimate is 1.2-fold (0.09 log units) above it, and the stated range covers the measured number.
By their numbers in the Free fatty acid receptor 1 assay, from the lowest: compounds 3, 2 and 1 (each within the scatter of the next).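

In the Free fatty acid receptor 1 assay compound 3 gives 13 nM and 4-hydroxy-1,1-dioxothian-4-yl in place of (ethylsulfonyl)methyl gives a 1.1-fold lower number from compound 2 to compound 3 (0.03 log units; within the scatter), and the same group in place of 2,4-dimethyl-1,3-thiazol-5-yl gives a 1.4-fold lower number from compound 1 to compound 3 (0.14 log units; within the scatter). The place on a saturated chain carbon bound to an oxygen on an aromatic ring therefore accepts a group with a six-membered non-aromatic ring and a hydrogen-bond donor, neither of which the earlier groups carry, with no step beyond the scatter. In a physicochemical assay for lipophilicity, read by HPLC, at pH 7.4 (on this read-out higher numbers stand for higher lipophilicity and lower numbers for lower lipophilicity), compound 2 gives 2.73 and compound 3 gives 2.43, and the exchange of (ethylsulfonyl)methyl for 4-hydroxy-1,1-dioxothian-4-yl gives a number 0.30 log units lower from compound 2 to compound 3 (within the scatter).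

Nothing shown offers an explanation for these small steps. Going by these compounds, it remains open whether 1,1-dioxothian-4-yl, which lacks the hydroxyl, or an amine or a carboxylic acid at this place would also stay within the scatter.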